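From pyridin-2-yl to thiophen-2-yl at an assay limit

The compounds below may be only part of what the source reports. "The series", "measured", "known", "first", "only" and "open" are said of these compounds alone.

Measured in a physicochemical assay, with a stated time of 30 min; on this read-out higher numbers stand for weaker inhibition and lower numbers for stronger inhibition:
- Compound 1 `C/C(=N\N=C1/SCC(=O)N1Cc1cccc(Cl)c1)c1cccs1`: > 5000000 nM (a limit)
- Compound 2 `C/C(=N/N=C1\SCC(=O)N1Cc1ccc(F)cc1)c1ccccn1`: > 5000000 nM (a limit)
- Compound 3 `C/C(=N\N=C1/SCC(=O)N1Cc1cccc(Cl)c1)c1ccccn1`: > 5000000 nM (a limit)

Compound 2 has only a limit, > 5000000 nM, and not a number. All three compounds stand together, with the limit of > 5000000 nM in this assay, at which 3 of the 3 values shown sit. Compound 4 `C/C(=N/N=C1\SCC(=O)N1Cc1ccc(F)cc1)c1cccs1` differs from compound 2 in one place: thiophen-2-yl in place of pyridin-2-yl on a carbon with a double bond to nitrogen. The nearest measured change exchanges the same two groups the other way round, and it is a step that the two limits leave unreadable from compound 1 to compound 3. It therefore offers no size or direction to carry over, so no definite step is expected in this assay. The estimated change is a number no higher from compound 2 to compound 4 (the limit leaves the size open). For compound 4 the expected value is about 5000000 nM, with an estimated range of 2000000 nM to 10000000 nM.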

Compound 4, half-maximal inhibitory concentration: > 5000000 nM
Compound 4 gave a limit, no number; the forecaster's own chance of this, stated with the estimate: 85%; the middle value lies on the limit itself.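

Compound 4, like compound 2, gave a limit and not a number, so no step can be read between them: the limit of > 5000000 nM in this assay, at which 4 of the 4 values shown sit.

The compounds shown leave open how strongly any of them inhibits, and whether thiophen-2-yl or pyridin-2-yl gives the stronger inhibition.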